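Cyclopentyl gives way to propyl

A few compounds are considered here, and "the series" means these few. Any claim that something is new, unique, unknown or untested is made for them only; others in the source may bear on it.

Compound 1 `Cc1nc(-c2nnn(C)c2COC(=O)N(C)CC2CCC2)ccc1O[C@H]1CCC[C@H](C(=O)O)C1`: 0.053
Compound 2 `Cc1nc(-c2nnn(C)c2COC(=O)N(C)CC2CCCC2)ccc1O[C@H]1CCC[C@H](C(=O)O)C1`: 0.047

In an ADME assay on the whole organism (plasma, Rattus norvegicus, strain Sprague-Dawley) for protein binding, read by LC-MS, with a stated time of 24 h (a lower number here means a smaller unbound share, a higher number a larger unbound share of the compound), compound 2 gives 0.047 and stands level with compound 1, the two lying within the usual scatter. Compound 3 `CCCCN(C)C(=O)OCc1c(-c2ccc(O[C@H]3CCC[C@H](C(=O)O)C3)c(C)n2)nnn1C` carries propyl in place of cyclopentyl on a saturated chain carbon bound to an amide-type nitrogen. For the measured compounds named here, the only measured step at this place, a 1.1-fold lower number from compound 1 to compound 2 (0.05 log units; within the scatter), stayed within the scatter, though it kept a ring and no measurement yet covers the loss of one. No shift beyond the scatter is therefore expected. The expected step is a 1.2-fold higher number from compound 2 to compound 3 (0.07 log units; within the scatter). For compound 3 the estimated value is 0.055, within an expected range of 0.033 to 0.095.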

Compound 3, unbound fraction: 0.063
Compound 3: middle estimate off by 1.1-fold (0.06 log units), on the low side; the range from low to high includes it.
By their numbers in this assay, from the lowest: compounds 2, 1 and 3 (each within the scatter of the next).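

In this assay, removing the ring altogether gives a 1.3-fold higher number from compound 2 to compound 3 (0.13 log units; within the scatter) and, set against the cyclobutyl compound, a 1.2-fold higher number from compound 1 to compound 3 (0.08 log units; within the scatter) and both steps stay within the scatter. Among these three compounds, then, the open-chain propyl reads the same as cyclobutyl and cyclopentyl, so a ring at this place is not needed to keep the number at this level. Nothing at hand explains this result. Going by these compounds, whether a longer chain, or an amine or a carboxylic acid at this place, would move the unbound fraction beyond the scatter remains open.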